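Aryl variation next to the ring nitrogen: compound 3

The source may hold more compounds than are shown below. What is called first, only, known or untested is meant among the compounds shown, and "the series" means these compounds.

Measured so far:
compound 1 `CC(C(=O)NCc1ccc(C(F)(F)F)nc1-c1ccc(Cl)cc1)c1ccc(NS(C)(=O)=O)c(F)c1` — 0.7 nM
compound 2 `COc1ccc(-c2nc(C(F)(F)F)ccc2CNC(=O)C(C)c2ccc(NS(C)(=O)=O)c(F)c2)cc1OC` — 25.6 nM

In an assay on CHO cells for antagonist activity at transient receptor potential cation channel subfamily V member 1 (Homo sapiens), read by FLIPR (on this read-out lower numbers stand for stronger inhibition and higher numbers for weaker inhibition), compound 1 gives 0.7 nM and compound 2 gives 25.6 nM. Among the compounds with values here, compound 2 stands at the highest number of the two; its only neighbour is compound 1, reached by a 37-fold higher number from compound 1 to compound 2 (1.56 log units; beyond the scatter), which is the single step recorded for this position.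

Compound 3 `CC(C(=O)NCc1ccc(C(F)(F)F)nc1-c1ccc2c(c1)OCCO2)c1ccc(NS(C)(=O)=O)c(F)c1` carries 2,3-dihydro-1,4-benzodioxin-6-yl in place of 3,4-dimethoxyphenyl on an aromatic carbon. The entering group matches the leaving one in the counts given and differs from it only by closing the two oxygen-bearing substituents into a non-aromatic ring fused to the aromatic ring.

Within the data shown here, the one step that bears on this change is a 37-fold higher number from compound 1 to compound 2 (1.56 log units; beyond the scatter). It shows that the group on this aromatic carbon shifts the number widely, yet it compares a 4-chlorophenyl with the 3,4-dimethoxyphenyl, not the 3,4-dimethoxyphenyl with its ring-closed counterpart. Among the measured compounds shown here, no direct precedent for the ring closure exists. Because a 37-fold higher number from compound 1 to compound 2 (1.56 log units; beyond the scatter) was large while the present change keeps the same counts, a moderate move downward, toward but not reaching compound 1, is expected, with wide uncertainty.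

Compound 3 is expected at 8 nM, with a range of 2 nM to 30 nM. The expected step is a 3.2-fold lower number from compound 2 to compound 3 (0.51 log units; beyond the scatter).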

Compound 3, inhibition constant: 5 nM
For compound 3 the middle estimate is 1.6-fold (0.20 log units) above the measured one; the range from low to high includes it.
By their numbers in this assay, from the lowest: compound 1; then compound 3; then compound 2.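

In this assay, closing the two oxygen-bearing substituents of the 3,4-dimethoxyphenyl into the 2,3-dihydro-1,4-benzodioxin-6-yl gives a 5.1-fold lower number from compound 2 to compound 3 (0.71 log units; beyond the scatter) even though the heavy-atom, donor and acceptor counts stay the same, so at this place next to the ring nitrogen the number depends on more than which atoms the aryl group carries. The ring-closed group does not close the whole gap to the 4-chlorophenyl, as a 7.1-fold higher number from compound 1 to compound 3 (0.85 log units; beyond the scatter) remains, and compound 1 keeps the lowest number of the three, with its steps to both others beyond the scatter. Nothing measured in this set accounts for the difference between the open and the ring-closed form.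

Still open, on these data alone, is whether the lower number belongs to this particular six-membered ring or to ring closure in general, which a 1,3-benzodioxol-5-yl group with its five-membered ring would test. Equally open, as far as these compounds go, is how far the number depends on the oxygens at all, a question for a phenyl carrying a single methoxy group, a 3,4-dichlorophenyl or a phenyl with a nitrile.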